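Dropping the Dimethylamino Group from an Aminothiazole Ketone

This account rests on a few compounds, and the source may have more. Where it says the series, first, only, none or still open, it means among the compounds named here.

The study gathers three measured compounds and one that awaits measurement. Compound 1 `Cc1cccn2c(C(=O)c3sc(N)nc3N(C)C)cnc12`, compound 2 `Cc1ccn2c(C(=O)c3sc(N)nc3C)cnc2c1` and compound 3 `Cc1ccc2ncc(C(=O)c3sc(N)nc3C)n2c1` were tested in a functional assay on the whole organism (strain Sprague-Dawley) for inhibition, with Rattus norvegicus as the target, read by paw edema, with stated times of 1 h and 3 h, at a dose of 50 mg/kg by the oral route; a lower number here means less inhibition, a higher number more inhibition at the dose given (going by the name of the read-out). Compound 1 gives 81% in this assay, compound 2 gives 66% and compound 3 gives 33%. Compound 1 therefore stands highest of the three numbers; compound 2 lies beneath it and compound 3 lies further beneath it, both gaps lying beyond the usual scatter. Compound 2 and compound 3 differ from compound 1 in more than one place, so their numbers show only that both fall short of compound 1, not which change is responsible.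

Compound 4 `Cc1cccn2c(C(=O)c3cnc(N)s3)cnc12` has not yet been measured in this assay. It differs from compound 1 in a single place: hydrogen in place of dimethylamino on an aromatic carbon. Among the compounds with values here, no measured pair shows this exact change, so the direction must be inferred. Since both compounds carrying a group other than dimethylamino at that carbon fall below compound 1, the step from compound 1 to compound 4 is expected to be a loss, of a size estimated at a number 26 percentage points lower from compound 1 to compound 4 (beyond the scatter). Compound 4 is accordingly expected to give about 55% in this assay, within a range from 25% to 80%.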

Compound 4, a percentage reported as inhibition, in the whole organism at one dose (the size of the read-out at that dose, not a potency): 31%
Estimate against measurement, compound 4: 24 percentage points above, and the stated range covers the measured number.
By their numbers in this assay, from the lowest: compounds 4 and 3 (each within the scatter of the next); then compound 2; then compound 1.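

In this assay, the exchange of dimethylamino for hydrogen on this aromatic carbon now has a measured size of its own, a large step of a number 50 percentage points lower from compound 1 to compound 4 (beyond the scatter) that lies beyond the scatter. The earlier compounds shown here differed from compound 1 in more than one place, so they could show only that both fell short of it, whereas this pair changes nothing else and ties the loss to this single position and this single change. The data at hand offer nothing that bears on why the step takes this size.

Going by these compounds, what remains open is how much of the dimethylamino group is needed on this carbon, since a single pair gives only the two ends of the change: whether a smaller amine such as methylamino, a larger one such as diethylamino, or a methoxy group there would stay close to compound 1 cannot be told from these compounds. Nor does this one step, read at a single oral dose, show whether the same exchange would cost as much on a core carrying its methyl group elsewhere.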